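Methoxy Gives Way to Nitro on the Shared Core

The source may hold more compounds than are shown below. What is called first, only, known or untested is meant among the compounds shown, and "the series" means these compounds.

In a functional assay on HepG2 cells (Homo sapiens) for cytotoxicity, read by MTT assay, with a stated time of 48 h (a lower number here means a stronger inhibitor, a higher number a weaker inhibitor), compound 3 (`COc1ccc2c(c1)nc(/C=C/C(=O)/C=C/c1ccc(OC)c(O)c1)n2C`) gives 4200 nM. This value lies within the scatter of both other measured compounds: compound 1 (`COc1cc(/C=C/C(=O)/C=C/c2nc3cc([N+](=O)[O-])ccc3n2C)ccc1O`) at 3700 nM and compound 2 (`COc1ccc(/C=C/C(=O)/C=C/c2nc3cc(C)ccc3n2C)cc1O`) at 3300 nM. Compound 3 therefore cannot be ranked against either of them.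

Compound 4 (`COc1ccc(/C=C/C(=O)/C=C/c2nc3cc([N+](=O)[O-])ccc3n2C)cc1O`) differs from compound 3 by a single change, nitro in place of methoxy on an aromatic carbon. Going by the values given here, one measured step bears directly on this carbon. This is a 1.3-fold higher number from compound 2 to compound 3 (0.10 log units; within the scatter), with methoxy in place of methyl, and it stays within the scatter. Compound 1 also bears a nitro group and gives 3700 nM, although its hydroxy and methoxy groups are arranged differently from those of compound 4. Among the compounds with values here, no measured pair compares nitro with methoxy directly, so the expectation rests on thin evidence. Even so, neither the single step nor the three values give reason to expect a shift beyond the scatter in this assay. The expected change is small, and the estimated step is a 1.1-fold lower number from compound 3 to compound 4 (0.04 log units; within the scatter). Compound 4 is expected at 3800 nM, with an estimated range of 1900 nM to 7500 nM.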

Compound 4, half-maximal inhibitory concentration: 4600 nM
For compound 4 the middle estimate is 1.2-fold (0.08 log units) below the measured one; measured number inside the range.
By their numbers in this assay, from the lowest: compounds 2, 1, 3 and 4 (each within the scatter of the next).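

In this assay, going by these compounds alone, the first direct comparison at this aromatic carbon, nitro in place of methoxy, gives a 1.1-fold higher number from compound 3 to compound 4 (0.04 log units; within the scatter) and stays within the scatter, and nitro in place of methyl gives a 1.4-fold higher number from compound 2 to compound 4 (0.14 log units; within the scatter) and also stays within the scatter. Across compounds 2, 3 and 4, which share the 3-hydroxy-4-methoxyphenyl group, methyl, methoxy and nitro on this carbon therefore cannot be told apart in this assay, and with nitro held on the shared core, 3-hydroxy-4-methoxyphenyl in place of 4-hydroxy-3-methoxyphenyl gives a 1.2-fold higher number from compound 1 to compound 4 (0.09 log units; within the scatter), so exchanging the hydroxy and methoxy groups on that ring cannot be read as a change either. Nothing shown here offers an explanation for this flat set of numbers.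

The compounds shown leave open whether any group on this carbon would carry the number beyond the scatter, for instance an amine, a carboxylic acid or a longer alkyl chain. They also leave open whether exchanging the hydroxy and methoxy groups would matter with methyl or methoxy rather than nitro on the shared core.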